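Side-chain swap at the amino acid residue of compound 1

A few compounds are considered here, and "the series" means these few. Any claim that something is new, unique, unknown or untested is made for them only; others in the source may bear on it.

Three compounds have been measured in a functional assay on the whole organism (Tail, strain ICR) with Mus musculus as the target, in the tail flick test, with a stated time of 30 min, at a dose of 25 umol/kg by the oral route; a higher number here means a stronger effect of the compound at the dose given, a lower number a weaker effect:

Compound 1, `C[C@@H](O)[C@H](NC(=O)CN(c1nc(Cl)nc2[nH]cnc12)C1CC1)C(=O)OCc1ccccc1`: 21.9%
Compound 2, `C[C@@H](O)[C@H](NC(=O)CN(c1nc(Cl)nc2[nH]cnc12)C1CC1)C(=O)O`: 18.6%
Compound 3, `CSCC[C@H](NC(=O)CN(c1ncnc2c1ncn2C1CCCCO1)C1CC1)C(=O)OCc1ccccc1`: 30%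

Among these three numbers compound 1 stands second highest. Its nearest neighbour is compound 2, with a number 3.3 percentage points lower from compound 1 to compound 2 (within the scatter); the furthest is compound 3, whose value lies higher than that of compound 1 but still within the scatter, so no order can be read among the three.

The unmeasured compound 4, `NC(=O)C[C@H](NC(=O)CN(c1nc(Cl)nc2[nH]cnc12)C1CC1)C(=O)OCc1ccccc1`, differs from compound 1 in one place: carbamoylmethyl in place of 1-hydroxyethyl on a saturated chain carbon bound to an amide-type nitrogen and a carbonyl carbon. Among the compounds with values here, no measured step touches this position, and the only step in hand, from the benzyl ester to the free acid, lay within the scatter. The carbamoylmethyl group enters where the 1-hydroxyethyl group leaves, keeping one hydrogen-bond donor and one acceptor, so nothing in the data points to a change beyond the scatter in this assay.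

Compound 4 is therefore expected to give 22% in this assay, between 10% and 36%, which means an estimated step of a number 0.1 percentage points higher from compound 1 to compound 4 (within the scatter).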

Compound 4, a percentage reported as activity, at one dose (the size of the read-out at that dose, not a potency): 24.4%
Compound 4: the middle estimate sits 2.4 percentage points below what was measured, and the stated range covers the measured number.
By their numbers in this assay, from the lowest: compounds 2, 1, 4 and 3 (each within the scatter of the next, the first and the last beyond it).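

In this assay, within the data shown here, replacing 1-hydroxyethyl with carbamoylmethyl on the saturated chain carbon bound to an amide-type nitrogen and a carbonyl carbon gives a number 2.5 percentage points higher from compound 1 to compound 4 (within the scatter) and provides the first reading at this position. At this dose, the position therefore tolerates this exchange without a change beyond the scatter, even though the defined stereocentre of the 1-hydroxyethyl group is lost and a double bond outside aromatic rings enters. Nothing available explains the size of this step.

From the compounds shown here alone, whether an amine, a carboxylic acid or a longer chain at this position would move the number beyond the scatter remains open. Also open, going by these compounds, is whether hydrogen in place of benzyl on the oxygen next to the carbonyl group would leave the number within the scatter when carbamoylmethyl is present.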